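Small Substituent Swap on a Weak Sulfonamide Series

The compounds below may be only part of what the source reports. "The series", "measured", "known", "first", "only" and "open" are said of these compounds alone.

- Compound 1 `CN(c1ccccc1)S(=O)(=O)C1CC2OC1C(c1ccc(NC(=O)CCCCCCC(=O)O)cc1)=C2c1ccc(O)cc1`: > 100000 nM (a limit)
- Compound 2 `CCN(c1ccccc1)S(=O)(=O)C1CC2OC1C(c1ccc(NC(=O)CCCCCCC(=O)O)cc1)=C2c1ccc(O)cc1`: > 100000 nM (a limit)
- Compound 3 `CCN(c1cccc(C)c1)S(=O)(=O)C1CC2OC1C(c1ccc(NC(=O)CCCCCCC(=O)O)cc1)=C2c1ccc(O)cc1`: 65600 nM

Among the compounds with values here, in a functional assay on DU-145 cells (Homo sapiens) for antiproliferative activity, read by MTT assay, with a stated time of 72 h (on this read-out higher numbers stand for weaker inhibition and lower numbers for stronger inhibition), compound 3 gives 65600 nM, the only actual number among the three measured compounds. Compound 1 and compound 2 stand at the limit of > 100000 nM in this assay, at which 2 of the 3 values shown sit.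

Compound 4 `CCN(c1ccc(OC)cc1)S(=O)(=O)C1CC2OC1C(c1ccc(NC(=O)CCCCCCC(=O)O)cc1)=C2c1ccc(O)cc1` differs from compound 3 in one place: 4-methoxyphenyl in place of 3-methylphenyl on a sulfonamide nitrogen. Here 4-methoxyphenyl takes the place of 3-methylphenyl on a sulfonamide nitrogen whose other neighbours are a saturated chain carbon and a sulfonyl sulfur.

Within the data shown here, two measured steps bear on this change. One is an at least 1.5-fold lower number from compound 2 to compound 3 (0.18 log units; that floor lies within the scatter), where methyl replaces hydrogen on an aromatic carbon. The other is an at least 1.5-fold lower number from compound 1 to compound 3 (0.18 log units; that floor lies within the scatter). Among the measured compounds shown here, neither gives a step beyond the scatter, and no measured compound carries the 4-methoxyphenyl group, so the data offer no direction for the swap.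

The expected result is therefore no change beyond the scatter in this assay, and a report of only a limit would be no surprise. The expected step is a 1.1-fold higher number from compound 3 to compound 4 (0.03 log units; within the scatter). The estimate for compound 4 is 70000 nM, with an expected range from 35000 nM to 100000 nM.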

Compound 4, half-maximal inhibitory concentration: 24400 nM
Compound 4: middle estimate off by 2.9-fold (0.46 log units), on the high side; the measured number lies below the stated range.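

In this assay, the aryl group on the sulfonamide nitrogen proves able to move the read-out beyond the scatter: 4-methoxyphenyl in place of 3-methylphenyl gives a 2.7-fold lower number from compound 3 to compound 4 (0.43 log units; beyond the scatter), whereas the methyl-bearing compound 3 had shown only floors within the scatter. Adding the methoxy group to the otherwise plain phenyl gives an at least 4.0-fold lower number from compound 2 to compound 4 (0.61 log units; beyond the scatter), so this substituent, unlike methyl, has a step from the plain phenyl compound that clears the scatter. The wider change, ethyl(4-methoxyphenyl)amino in place of methyl(phenyl)amino on a sulfonyl sulfur, gives an at least 4.0-fold lower number from compound 1 to compound 4 (0.61 log units; beyond the scatter), and this step and the one from compound 2 are floors rather than full sizes because both starting compounds stand at a limit: the limit of > 100000 nM in this assay, at which 2 of the 4 values shown sit.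

Compound 3 and compound 4 differ in both the substituent and where it sits on the ring, so the compounds shown cannot tell which of the two accounts for the step. Going by these compounds, how an ethoxy group, a hydroxy group or a fluorine on that ring would read also stays open, as does whether a longer chain on the sulfonamide nitrogen in place of ethyl would keep the lower number.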